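The source may report more compounds than this note shows. Statements on the series, on what has been measured and on what is new or still open speak of the compounds shown alone.

Measured so far
compound 1 `CCCCCCCCOP(=O)(O)OCCSC(=S)N1CCCC1` gives 53000 nM in the series
compound 2 `CCCCCCCCCCOP(=O)(O)OCCSC(=S)N1CCN(C)CC1` gives 99600 nM in the series

Both numbers come from a functional assay on MCF7 cells (Homo sapiens) for inhibition, read by MTT assay, with stated times of 18 h and 4 h; a lower number here means a stronger inhibitor, a higher number a weaker inhibitor. Compound 2 at 99600 nM lies within the usual scatter of compound 1 at 53000 nM, so the two cannot be ranked.

Next is compound 3 `CCCCCCCCOP(=O)(O)OCCSC(=S)N1CCN(C)CC1`, not yet measured. Relative to compound 2, the change is hydrogen in place of ethyl on a saturated chain carbon, eight bonds along the chain from an oxygen on an unsaturated carbon in the chain: hydrogen in place of ethyl on a saturated chain carbon, eight bonds along the chain from an oxygen on an unsaturated carbon. Cut one bond further out, the same difference reads butyl to ethyl. Among the measured compounds shown here, no measured pair isolates this change, so the data give no direct guide to its size or direction.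

In this assay no step beyond the scatter is expected, and compound 2 at 99600 nM serves as the starting point. The estimated 1.1-fold lower number from compound 2 to compound 3 (0.04 log units; within the scatter) is expected to stay within the scatter. For compound 3 the expected value is 90000 nM, with an estimated range of 40000 nM to 200000 nM as the working span.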

Compound 3, half-maximal inhibitory concentration: 46000 nM
Estimate against measurement, compound 3: 2.0-fold (0.29 log units) above; low and high end bracket the measured number.
By their numbers in this assay, from the lowest: compounds 3, 1 and 2 (each within the scatter of the next, the first and the last beyond it).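

In this assay, the series now has its first step that isolates a change in the chain: hydrogen in place of ethyl on a saturated chain carbon, eight bonds along the chain from an oxygen on an unsaturated carbon, gives a 2.2-fold lower number from compound 2 to compound 3 (0.34 log units; beyond the scatter). This step lies beyond the scatter but is modest, and it shows that, with 4-methylpiperazin-1-yl held fixed, the shorter chain gives the lower number. The second comparison, 4-methylpiperazin-1-yl in place of pyrrolidin-1-yl on a thiocarbonyl carbon, gives a 1.2-fold lower number from compound 1 to compound 3 (0.06 log units; within the scatter), so with the chain held fixed these two groups cannot be ranked, and nothing at hand bears on the origin of either step.

From the compounds shown here alone, the chain step rests on a single pair, so it remains open whether it holds with pyrrolidin-1-yl on the thiocarbonyl carbon and whether the numbers keep falling with a hexyl chain or rise again with a dodecyl chain. Also open, going by these compounds, is how a morpholin-4-yl group on the thiocarbonyl carbon, or a carboxylic acid or an amine carried on the chain, would read in this assay.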